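Chain terminus variation on the shared core in rat

A few compounds are considered here, and "the series" means these few. Any claim that something is new, unique, unknown or untested is made for them only; others in the source may bear on it.

Measured so far in a functional assay on the whole organism with Rattus norvegicus as the target; on this read-out higher numbers stand for an effect only at larger amounts of compound and lower numbers for an effect already at smaller amounts:
compound 1, `CCCn1c(=N)sc2cc(OC(F)(F)F)ccc21`: 4.5 mg/kg
compound 3, `CSCn1c(=N)sc2cc(OC(F)(F)F)ccc21`: 3 mg/kg
compound 2, `N=c1sc2cc(OC(F)(F)F)ccc2n1Cc1ccccc1`: reaches only the assay limit, > 10 mg/kg

Compound 1 stands highest of the two actual numbers in this assay, its nearest neighbour being compound 3, with a 1.5-fold lower number from compound 1 to compound 3 (0.18 log units; within the scatter). Compound 2 gives no number, only a limit (the limit of > 10 mg/kg in this assay, at which 1 of the 3 values shown sits). The step of an at least 2.2-fold higher number from compound 1 to compound 2 (0.34 log units; beyond the scatter) is beyond the scatter, and so is an at least 3.3-fold lower number from compound 2 to compound 3 (0.52 log units; beyond the scatter).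

Compound 4, `N=c1sc2cc(OC(F)(F)F)ccc2n1CC[S+]([O-])c1ccccc1`, differs from compound 1 by a group of 8 heavy atoms (6 carbon, 1 oxygen, 1 sulfur; one six-membered aromatic ring of carbon only) in place of one carbon atom, on a saturated chain carbon, two bonds along the chain from an aromatic nitrogen. The step from compound 1 to compound 2 bears most directly on it, since a six-membered aromatic ring of carbon enters there too and the dose rose. The step from compound 1 to compound 3, where a sulfur entered, stayed within the scatter. A modest rise in dose is therefore expected, a 2.0-fold higher number from compound 1 to compound 4 (0.30 log units; within the scatter). Compound 4 is estimated at 9 mg/kg, within 4 mg/kg to 20 mg/kg; a limit rather than a number is a real possibility.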

Compound 4, dose for half-maximal effect: 4.2 mg/kg
Compound 4: middle estimate off by 2.1-fold (0.33 log units), on the high side; low and high end bracket the measured number.
By their numbers in this assay, from the lowest: compounds 3, 4 and 1 (each within the scatter of the next). At a limit, above all of these: compound 2.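

At this position, on a saturated chain carbon, a group of 8 heavy atoms with a six-membered aromatic ring of carbon only is accepted in this assay without a shift beyond the scatter: the step is a 1.1-fold lower number from compound 1 to compound 4 (0.03 log units; within the scatter). The earlier reading, in which an aromatic ring on the chain went with a higher dose, therefore does not hold across the series, and compound 4 goes against it. Compound 2, which also carries such a ring on the chain, remains at a limit: the limit of > 10 mg/kg in this assay, at which 1 of the 4 values shown sits.

The compounds shown do not separate the role of the chain length from that of the sulfur-oxygen link in compound 4. Going by these compounds, it also remains open how a sulfone, a plain thioether, an amine or a carboxylic acid at the chain end would behave here.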